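This account rests on a few compounds, and the source may have more. Where it says the series, first, only, none or still open, it means among the compounds named here.

The measured compounds, with their values in a physicochemical assay for lipophilicity; a lower number here means a more polar compound, a higher number a more lipophilic compound:

Compound 1, `CCOC(=O)/C=C(C)/C=C/CC(C)CCCC(C)(C)C`, gives 7.15.
Compound 2, `CCOC(=O)/C=C(C)/C=C/CC(C)CCC(OC)C(C)C`, gives 5.54.
Compound 3, `CC(/C=C/CC(C)CCCC(C)(C)C)=C\C(=O)OC(C)C`, gives 7.56.

Compound 4, `COC(CCC(C)C/C=C/C(C)=C/C(=O)OC(C)C)C(C)C`, has not yet been measured in this assay.

Two of the measured compounds differ by a single change: 1-methoxy-2-methylpropyl in place of neopentyl on a saturated chain carbon, four bonds along the chain from a double-bonded chain carbon. That change brought a number 1.61 log units lower from compound 1 to compound 2 (beyond the scatter). Compound 3 stands apart from compound 1 by a different change, (methyl in place of hydrogen on a saturated chain carbon bound to an oxygen next to a carbonyl group and a saturated chain carbon), which gave a number 0.41 log units higher from compound 1 to compound 3 (beyond the scatter). Compound 4 carries both changes at once: against compound 3 it shows (1-methoxy-2-methylpropyl in place of neopentyl on a saturated chain carbon, four bonds along the chain from a double-bonded chain carbon). The description of where this change sits is the same, word for word, as for the change between compound 1 and compound 2, so it is the same change, made this time on the core of compound 3 rather than on the core of compound 1.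

Among the compounds with values here, with only one earlier instance of this change, the expectation has to rest on it alone. Compound 4 is expected to lie close to 5.95 in this assay, most likely between 5.5 and 6.4. Within the data shown here, that estimate means a step of a number 1.61 log units lower from compound 3 to compound 4 (beyond the scatter), expected to be about as large as the measured one because a number 1.61 log units lower from compound 1 to compound 2 (beyond the scatter) is the only guide available and the two changes are the same. Among the three measured compounds, compound 3 stands highest and compound 2 lowest; compound 4 is expected to fall between them.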

Compound 4, partition coefficient: 5.95
The estimate for compound 4 equals the measured number at the digits printed; measured number inside the range.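

In this assay, putting 1-methoxy-2-methylpropyl in place of neopentyl gives a number 1.61 log units lower from compound 3 to compound 4 (beyond the scatter) and matches in size a number 1.61 log units lower from compound 1 to compound 2 (beyond the scatter) on the other core, so this change carried over from the core of compound 1 to the core of compound 3 with no loss or gain at the digits printed. The second change, methyl in place of hydrogen on the saturated chain carbon bound to the oxygen, tells the same story from the other side: it gives a number 0.41 log units higher from compound 2 to compound 4 (beyond the scatter) and matches in size a number 0.41 log units higher from compound 1 to compound 3 (beyond the scatter), so in compound 4 the two changes simply add up in this assay. This is still only one repeat on two closely similar cores, which does not make it a rule for the series, and no measurement on hand explains why the two changes add up in this way.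

The compounds shown leave open whether 1-methoxy-2-methylpropyl would bring a step of this size to a core carrying a carboxylic acid or an amine. They also leave open what a longer chain in place of neopentyl would do, and whether the two changes would still add up there.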